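Compound 4 in a cytotoxicity assay, weighed from compound 3

A few compounds are considered here, and "the series" means these few. Any claim that something is new, unique, unknown or untested is made for them only; others in the source may bear on it.

Measured compounds:
compound 1, `CN(C)CCn1cnnc1-c1cc(Oc2ccc(NC(=O)N/N=C/c3c[nH]c4ccccc34)cc2F)ccn1`, 3620 nM
compound 2, `COc1cc(/C=N/NC(=O)Nc2ccc(Oc3ccnc(-c4nncn4CCN(C)C)c3)c(F)c2)cc(OC)c1OC`, "not determined" (no result reported)
compound 3, `CN(C)CCn1cnnc1-c1cc(Oc2ccc(NC(=O)N/N=C/c3cccc(Cl)c3Cl)cc2F)ccn1`, 6130 nM
compound 4, `COc1cc(/C=N/NC(=O)Nc2ccc(Oc3ccnc(-c4nncn4CCN(C)C)c3)c(F)c2)ccc1O`, not yet measured

In an ADME assay on WI-38 cells (Homo sapiens) for cytotoxicity, read by MTT assay, with a stated time of 72 h (a higher number here means a weaker inhibitor, a lower number a stronger inhibitor), compound 3 gives 6130 nM, the highest of the two numbers reported. The nearest is compound 1, which in this assay gives 3620 nM; the step of a 1.7-fold higher number from compound 1 to compound 3 (0.23 log units; within the scatter) is within the scatter. Compound 2 has no result in this assay.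

Compound 4 differs from compound 3 in one place: 4-hydroxy-3-methoxyphenyl in place of 2,3-dichlorophenyl on a carbon with a double bond to nitrogen. Among the compounds with values here, the only measured step that bears on this change is the one from compound 1 to compound 3, which also exchanges the group on the carbon with a double bond to nitrogen, and that step, a 1.7-fold higher number from compound 1 to compound 3 (0.23 log units; within the scatter), did not rise above the scatter. On that basis the expected step of a 1.4-fold lower number from compound 3 to compound 4 (0.13 log units; within the scatter) is none beyond the scatter, in either direction. Compound 4 is therefore estimated at 4500 nM in this assay, with a range from 1500 nM to 14000 nM.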

Compound 4, half-maximal inhibitory concentration: 5320 nM
Compound 4: the middle estimate sits 1.2-fold (0.07 log units) below what was measured, and the stated range covers the measured number.
By their numbers in this assay, from the lowest: compounds 1, 4 and 3 (each within the scatter of the next).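

The steps of a 1.2-fold lower number from compound 3 to compound 4 (0.06 log units; within the scatter) and a 1.5-fold higher number from compound 1 to compound 4 (0.17 log units; within the scatter) show in this assay that 4-hydroxy-3-methoxyphenyl on a carbon with a double bond to nitrogen cannot be told apart, within the scatter, from either 2,3-dichlorophenyl or 1H-indol-3-yl. The earlier compounds shown here offered a single exchange at this place; now a group with oxygen atoms instead of chlorine, carrying a hydrogen-bond donor and acceptors that 2,3-dichlorophenyl lacks, also stays within the scatter. No supporting measurement bears on this result.

As far as these compounds go, it remains open whether any group at this place can move the number beyond the scatter, for instance a ring carrying a carboxylic acid or an amine. Also open, from the compounds shown here alone, is how far the number depends on the shared core, which all these compounds keep.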